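Piperidine carbonylamino groups on a pyrazole amide series

The compounds below may be only part of what the source reports. "The series", "measured", "known", "first", "only" and "open" are said of these compounds alone.

Measured compounds:
compound 1 `Cc1cc(C(=O)NN2CCOCC2)nn1Cc1cc(Cl)cc2cc(-c3ccccc3)oc12`: 10 nM
compound 2 `Cc1cc(C(=O)NC(C)(C)C)nn1Cc1cc(Cl)cc2cc(-c3ccccc3)oc12`: 10 nM
compound 3 `Cc1cc(NC(=O)CC2CCNCC2)nn1Cc1cc(Cl)cc2cc(-c3ccccc3)oc12`: 63.1 nM

In an assay on CHO-K1 cells for displacement of a labelled ligand from prostaglandin E2 receptor EP1 subtype (Homo sapiens), read by scintillation counting, with a stated time of 45 min (on this read-out lower numbers stand for stronger inhibition and higher numbers for weaker inhibition), compound 1 gives 10 nM. Compound 1 stands level with compound 2, and these two share the lowest numbers of the three; compound 3 lies furthest away, a 6.3-fold higher number from compound 1 to compound 3 (0.80 log units; beyond the scatter). The step to compound 4 `Cc1cc(NC(=O)C2(F)CCNCC2)nn1Cc1cc(Cl)cc2cc(-c3ccccc3)oc12` is ((4-fluoropiperidin-4-yl)carbonyl)amino in place of (morpholin-4-yl)carbamoyl on an aromatic carbon. Going by the values given here, no measured pair shows this exact change. The closest guide is compound 3, which also carries a carbonylamino group joined to a piperidine ring on the same aromatic carbon: its steps were a 6.3-fold higher number from compound 1 to compound 3 (0.80 log units; beyond the scatter) and a 6.3-fold higher number from compound 2 to compound 3 (0.80 log units; beyond the scatter), both modest and beyond the scatter. Exchanging the amide-type nitrogen substituent alone, no change at the digits printed from compound 1 to compound 2 (within the scatter), changed nothing. A step of similar size and direction is therefore expected for compound 4, with wider uncertainty given the fluorine and the shorter link to the piperidine ring. Compound 4 is expected to give 50 nM, within 15 nM to 200 nM, an expected step of a 5.0-fold higher number from compound 1 to compound 4 (0.70 log units; beyond the scatter).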

Compound 4, half-maximal inhibitory concentration: 39.8 nM
Estimate against measurement, compound 4: 1.3-fold (0.10 log units) above; the measured number falls inside the stated range.
By their numbers in this assay, from the lowest: compounds 1 and 2 (each within the scatter of the next); then compounds 4 and 3 (each within the scatter of the next).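

In this assay the ((4-fluoropiperidin-4-yl)carbonyl)amino group on this aromatic carbon gives a 4.0-fold higher number from compound 1 to compound 4 (0.60 log units; beyond the scatter) and a 4.0-fold higher number from compound 2 to compound 4 (0.60 log units; beyond the scatter), so compound 3 is no longer alone among the carbonylamino compounds in standing apart from the two carbamoyl compounds. Replacing (piperidin-4-yl)methyl with 4-fluoropiperidin-4-yl on the carbonyl carbon gives a 1.6-fold lower number from compound 3 to compound 4 (0.20 log units; within the scatter), so these two groups cannot be told apart in this read-out. Nothing available here bears on what lies behind these numbers.

On these data alone, the fluorine and the shorter link to the piperidine ring change together, so their separate contributions remain open; a plain piperidin-4-yl group on the carbonyl carbon would divide them. As far as these compounds go, whether a morpholin-4-yl group on that carbonyl carbon would bring the number back towards that of compound 1 also remains open.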